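Working notes on aryl variation in the series

The source may hold more compounds than are shown below. What is called first, only, known or untested is meant among the compounds shown, and "the series" means these compounds.

Measured compounds:
- compound 1 `CC1=CC[C@@H]([C@@](C)(O)CCCC(C)(C)NC(=S)N/N=C\c2ccc(N(C)C)cc2)CC1`: in a functional assay on NCI/ADR cells (Homo sapiens) for cytotoxicity, read by sulforhodamine B assay (on this read-out lower numbers stand for stronger inhibition of growth and higher numbers for weaker inhibition of growth), compound 1 gives > 100000 nM, which is a limit of the assay.
- compound 2 `CC1=CC[C@@H]([C@@](C)(O)CCCC(C)(C)NC(=S)N/N=C\c2ccccc2[N+](=O)[O-])CC1`: compound 2 gives > 100000 nM, again a limit of the assay.
- compound 3 `CC1=CC[C@@H]([C@@](C)(O)CCCC(C)(C)NC(=S)N/N=C\c2cccc([N+](=O)[O-])c2)CC1`: compound 3 gives 38000 nM.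

Within the data shown here, compound 3 therefore stands as the only compound of the three with an actual number; the other two values sit at the limit of > 100000 nM in this assay, at which 2 of the 3 values shown sit. The two steps that end at compound 3, an at least 2.6-fold lower number from compound 1 to compound 3 (0.42 log units; beyond the scatter) and an at least 2.6-fold lower number from compound 2 to compound 3 (0.42 log units; beyond the scatter), are both readable only as lower bounds, since they start from a limit.

Compound 4 `CC1=CC[C@@H]([C@@](C)(O)CCCC(C)(C)NC(=S)N/N=C\c2ccccc2Cl)CC1` is not yet measured. The change from compound 3 is 2-chlorophenyl in place of 3-nitrophenyl on a carbon with a double bond to nitrogen. Among the measured compounds shown here, no measured step involves a chlorophenyl group. The closest guidance is an at least 2.6-fold lower number from compound 2 to compound 3 (0.42 log units; beyond the scatter), in which a 2-substituted phenyl gave a limit and the 3-substituted one gave a number; compound 4 returns to a 2-substituted phenyl, so a step back up toward the limit is expected, a 2.1-fold higher number from compound 3 to compound 4 (0.32 log units; beyond the scatter). Compound 4 is estimated at 80000 nM, with a range from 30000 nM to 200000 nM, and a fair chance that only a limit is reported.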

Compound 4, concentration for total growth inhibition: > 100000 nM
Compound 4: no number, only a limit (the forecaster's own chance of this, stated with the estimate: 50%); middle value at least 1.2-fold (0.09 log units) from the limit.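

In this assay, 2-chlorophenyl in place of 3-nitrophenyl on a carbon with a double bond to nitrogen gives an at least 2.6-fold higher number from compound 3 to compound 4 (0.42 log units; beyond the scatter), a step readable only as a lower bound. The steps from compound 2 to compound 4 and from compound 1 to compound 4 have limits at both ends and cannot be read. With neither 2-nitrophenyl nor 2-chlorophenyl giving a number, compound 3 remains the only compound with one: the limit of > 100000 nM in this assay, at which 3 of the 4 values shown sit.

Open, from the compounds shown here alone, is whether the number of compound 3 belongs to the nitro group or to the 3-substituted pattern, a question that 3-chlorophenyl or 4-nitrophenyl in the same place would address. Also open, going by these compounds, is how far compound 1, compound 2 and compound 4 differ from one another beyond their shared limit.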